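A few compounds are considered here, and "the series" means these few. Any claim that something is new, unique, unknown or untested is made for them only; others in the source may bear on it.

Compound 1 `CCCN(CCC)c1cccc2nc(Nc3c(C)cc(C)cc3C)c(=O)[nH]c12`: 100 nM
Compound 2 `COCc1cc(OC)c(Oc2nc3cccc(N(CC4CCOCC4)CC4CC4)c3cc2C)c(OC)c1`: 762 nM

Both were tested in an assay on HEK293 cells for displacement of a labelled ligand from corticotropin-releasing factor receptor 1 (Homo sapiens), read by scintillation proximity assay, with a stated time of 2 h; on this read-out lower numbers stand for stronger inhibition and higher numbers for weaker inhibition. Within the data shown here, of the two numbers, compound 2 holds the higher one, with 762 nM; its only neighbour, compound 1, sits at a lower number, and that gap is beyond the usual scatter of the measurement.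

Compound 3 `CCN(CC)c1cccc2nc(Oc3c(OC)cc(COC)cc3OC)c(C)cc12` has not yet been measured. It differs from compound 2 in a single place: diethylamino in place of (cyclopropylmethyl)((oxan-4-yl)methyl)amino on an aromatic carbon. Among the measured compounds shown here, no pair of measured compounds shows this exact exchange, so the expectation rests only on the two numbers above. Compound 1 also carries a simple dialkylamino group with two short chains, though on a different core, which limits what it can say here. A modest step seems likely, probably toward a lower number and not far beyond the scatter. The step from compound 2 to compound 3 is expected to be a 1.7-fold lower number from compound 2 to compound 3 (0.23 log units; within the scatter). Compound 3 is thus estimated at 450 nM, within 150 nM to 1500 nM.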

Compound 3, half-maximal inhibitory concentration: 70 nM
For compound 3 the middle estimate is 6.4-fold (0.81 log units) above the measured one, and the stated range ends above it.
By their numbers in this assay, from the lowest: compounds 3 and 1 (each within the scatter of the next); then compound 2.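

In this assay, the amino group on this aromatic carbon of the shared core proves to have a strong influence on the result: putting diethylamino in place of (cyclopropylmethyl)((oxan-4-yl)methyl)amino gives an 11-fold lower number from compound 2 to compound 3 (1.04 log units; beyond the scatter). The position therefore accepts the smaller diethylamino, which has no ring, and the exchange goes with stronger inhibition rather than a loss of it. Nothing shown here gives a measured reason for a step of this size.

Both arms of the amine change together in this exchange, so the compounds shown cannot say whether the cyclopropylmethyl arm, the oxan-4-ylmethyl arm or the two together account for the step. They also leave open how a mixed ethyl(cyclopropylmethyl)amino group or a longer dibutylamino group would behave at this position on the shared core.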